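Swapping the aryl group on a triazole hydroxamate

The source may report more compounds than this note shows. Statements on the series, on what has been measured and on what is new or still open speak of the compounds shown alone.

Compound 1, `Cc1ccc(-c2nc(CNc3ccc(C(=O)NO)cc3)n(-c3ccccc3)n2)cc1`: 62.2%
Compound 2, `O=C(NO)c1ccc(NCc2nc(-c3ccco3)nn2-c2ccccc2)cc1`: 59.9%
Compound 3, `Cc1cccc(-c2nc(CNc3ccc(C(=O)NO)cc3)n(-c3ccccc3)n2)c1`: 64.1%

All three numbers come from an assay on Sf9 cells for inhibition of protein deacetylase HDAC6 (Homo sapiens), read by fluorescence, with a stated time of 40 min, tested at 100 nM; on this read-out higher numbers stand for more inhibition at the one concentration tested (going by the name of the read-out) and lower numbers for less inhibition. Compound 1 holds the second highest of the three; its nearest neighbour lies a number 1.9 percentage points higher from compound 1 to compound 3 (within the scatter) and its furthest a number 2.3 percentage points lower from compound 1 to compound 2 (within the scatter), so the three sit within the usual scatter of one another. Compound 4, `O=C(NO)c1ccc(NCc2nc(-c3ccccn3)nn2-c2ccccc2)cc1`, has not yet been measured. It differs from compound 1 in one place: pyridin-2-yl in place of 4-methylphenyl on an aromatic carbon. Both measured steps from compound 1 alter this very group, and neither moved the read-out beyond the scatter. On that basis no change beyond the scatter is expected for compound 4 in this assay, an expected step of a number 2.2 percentage points lower from compound 1 to compound 4 (within the scatter). Compound 4 is therefore estimated at 60%, between 48% and 72%.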

Compound 4, a percentage reported as inhibition, at one concentration (the size of the read-out at that concentration, not a potency): 58.6%
Compound 4: middle estimate off by 1.4 percentage points, on the high side; measured number inside the range.
By their numbers in this assay, from the lowest: compounds 4, 2, 1 and 3 (each within the scatter of the next).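

Compound 4 carries a six-membered ring with a ring nitrogen, counted as a hydrogen-bond acceptor, which the earlier groups at this position lack. Even so, the steps of a number 3.6 percentage points lower from compound 1 to compound 4 (within the scatter) and a number 5.5 percentage points lower from compound 3 to compound 4 (within the scatter) and a number 1.3 percentage points lower from compound 2 to compound 4 (within the scatter) are all small in this assay and do not separate pyridin-2-yl from the other groups. Nothing available explains this flat picture.

From the compounds shown here alone, all four groups are aromatic rings, so it remains open how a saturated amine such as piperidine or a carboxylic acid would read here. A single concentration also leaves any differences in potency open.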